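From Trifluoromethyl to Amino: an Expected Shift

The source may report more compounds than this note shows. Statements on the series, on what has been measured and on what is new or still open speak of the compounds shown alone.

Measured in an assay for inhibition of MAP kinase-interacting serine/threonine-protein kinase 1 (Homo sapiens), read by luminescence and ADP-Glo, with a stated time of 2 h; a lower number here means a stronger inhibitor, a higher number a weaker inhibitor:
- compound 1 `CC(=O)Nc1cccc(Cn2cc(-c3ccc4cn[nH]c4c3)ccc2=O)c1` gives 163 nM
- compound 2 `O=C(N1CCOCC1)n1cc(-c2ccc3cn[nH]c3c2)ccc1=O` gives > 2000 nM, which is a limit of the assay and not a number
- compound 3 `O=c1ccc(-c2ccc3cn[nH]c3c2)cn1Cc1cccc(C(F)(F)F)c1` gives 40 nM

Compound 3 holds the lowest of the two numbers shown. Among the compounds with values here, the only step measured between these compounds, a 4.1-fold lower number from compound 1 to compound 3 (0.61 log units; beyond the scatter), lies beyond the scatter, so the group on that aromatic carbon matters.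

Compound 4 `Nc1cccc(Cn2cc(-c3ccc4cn[nH]c4c3)ccc2=O)c1` has not yet been measured. It differs from compound 3 by amino in place of trifluoromethyl on an aromatic carbon. The measured step that bears on this is a 4.1-fold lower number from compound 1 to compound 3 (0.61 log units; beyond the scatter), in which replacing acetamido by trifluoromethyl lowered the number. Compound 4 moves back away from trifluoromethyl toward a small group with a hydrogen-bond donor and acceptor, so the expected step of a 3.8-fold higher number from compound 3 to compound 4 (0.57 log units; beyond the scatter) points the other way, toward a higher number, and is expected to be modest. Compound 4 is therefore estimated to give about 150 nM in this assay, with an expected range from 50 nM to 500 nM.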

Compound 4, half-maximal inhibitory concentration: 287 nM
For compound 4 the middle estimate is 1.9-fold (0.28 log units) below the measured one, within the range that was stated.
By their numbers in this assay, from the lowest: compound 3; then compounds 1 and 4 (each within the scatter of the next). At a limit, above all of these: compound 2.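

On this aromatic carbon of the six-membered ring, amino in place of trifluoromethyl gives a 7.2-fold higher number from compound 3 to compound 4 (0.86 log units; beyond the scatter) in this assay, so the small gain seen with trifluoromethyl does not carry over to the smaller group. Taking the acetyl off the nitrogen gives a 1.8-fold higher number from compound 1 to compound 4 (0.25 log units; within the scatter), so amino and acetamido cannot be told apart here, and both stand apart from trifluoromethyl. With 3-aminobenzyl in place of (morpholin-4-yl)carbonyl on the aromatic nitrogen the step is an at least 6.9-fold lower number from compound 2 to compound 4 (0.84 log units; beyond the scatter), and compound 2 gives only a limit, not a number: the limit of > 2000 nM in this assay, at which 1 of the 4 values shown sits.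

With only three groups shown on this carbon, it remains open whether a methyl group or a chlorine atom would stay close to trifluoromethyl. Going by these compounds, how a carboxylic acid or a longer chain would fare there is also open.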